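Methyl for Hydrogen on a Ring Oxygen, Compound 4

The compounds below may be only part of what the source reports. "The series", "measured", "known", "first", "only" and "open" are said of these compounds alone.

Compound 1 `COc1ccc2c(=O)cc(/C=C/[S+](C)[O-])oc2c1O` gives in a functional assay on A549 cells (Homo sapiens) for inhibition, with a stated time of 48 h (on this read-out higher numbers stand for weaker inhibition and lower numbers for stronger inhibition), only the limit > 10000 nM. Compound 2 `COc1ccc2c(=O)cc(/C=C/[S+](C)[O-])oc2c1OC` carries methyl in place of hydrogen on an oxygen on an aromatic ring, and in this assay compound 2 also reaches only the limit > 10000 nM. The step that the two limits leave unreadable from compound 1 to compound 2 therefore cannot be read, since the limit of > 10000 nM in this assay, at which 3 of the 3 values shown sit, holds both values. Compound 3 `C[S+]([O-])/C=C/c1cc(=O)c2cc(O)ccc2o1` shows in this assay only the limit > 10000 nM. The difference between the core of compound 3 and that of compound 1 is not broken down here. Compound 4 `COc1ccc2oc(/C=C/[S+](C)[O-])cc(=O)c2c1` differs from compound 3 by methyl in place of hydrogen on an oxygen on an aromatic ring, the same change that leads from compound 1 to compound 2. The step that the limit leaves unreadable from compound 3 to compound 4 is expected to stay unreadable, because a step that the two limits leave unreadable from compound 1 to compound 2 left both compounds at the limit. Compound 4 is estimated at 20000 nM, most likely reported as a limit, between 8000 nM and 100000 nM.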

Compound 4, half-maximal inhibitory concentration: 9000 nM
Beside the measured number, compound 4's estimate is 2.2-fold (0.35 log units) above it; the range from low to high includes it.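

In this assay, methyl in place of hydrogen on an oxygen on an aromatic ring gives an at least 1.1-fold lower number from compound 3 to compound 4 (0.04 log units; that floor lies within the scatter); this is only a floor, so it neither shows nor excludes a real difference between the two. Compound 3 is known only by a limit, > 10000 nM. The same change on the core of compound 1 cannot be read, so this result does not show that the change carries from one core to the other, because nearly all the values rest on one limit: the limit of > 10000 nM in this assay, at which 3 of the 4 values shown sit.

The compounds shown leave open what a longer chain on that oxygen, or an amine in place of the hydroxy, would do to the read-out. They also leave open how this change behaves on any core where both partners give a measured number.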